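Swapping Halogens on the Aryl Ring of Compound 1

The source may hold more compounds than are shown below. What is called first, only, known or untested is meant among the compounds shown, and "the series" means these compounds.

Compound 1 `O=C(Nc1cc2cc[nH]c(=O)c2cc1Cl)C1CNCC1c1ccc(F)cc1` was tested in an assay on isolated protein for inhibition of Rho-associated protein kinase 2 (Homo sapiens), read by a luciferase reporter (a lower number here means a stronger inhibitor, a higher number a weaker inhibitor), where compound 1 gives 9 nM. Among the three compounds measured, it stands second highest. Compound 3 `O=C(Nc1cc2cc[nH]c(=O)c2cc1Cl)C1CNCCC1c1ccccc1` gives 6 nM, a number within the usual scatter of that of compound 1, so the two cannot be ordered. Compound 2 `NCC(=O)Nc1cc2cc[nH]c(=O)c2cc1Cl` lacks the ring-bearing amide part that compound 1 and compound 3 share. In this assay compound 2 gives 120 nM, a far higher number and well beyond the scatter.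

Compound 4 `O=C(Nc1cc2cc[nH]c(=O)c2cc1Cl)C1CNCC1c1ccc(Cl)cc1Cl` has not been measured. It differs from compound 1 by 2,4-dichlorophenyl in place of 4-fluorophenyl on a saturated ring carbon. Among the compounds with values here, no measured pair shows this kind of change, so there is no step to lean on. The shared core and the amide part are unchanged, and compound 2 shows that the amide part carries much of the potency, while the swap of one halogenated ring for another is a smaller move. The expected step of a 1.7-fold higher number from compound 1 to compound 4 (0.22 log units; within the scatter) is therefore small, likely none beyond the scatter, with a slight lean toward a higher number. Compound 4 is estimated at 15 nM, with a range from 5 nM to 45 nM.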

Compound 4, half-maximal inhibitory concentration: 8 nM
The estimate for compound 4 lay 1.9-fold (0.27 log units) above the measured number; the range from low to high includes it.
By their numbers in this assay, from the lowest: compounds 3, 4 and 1 (each within the scatter of the next); then compound 2.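

In this assay, 2,4-dichlorophenyl in place of 4-fluorophenyl on this saturated ring carbon gives a 1.1-fold lower number from compound 1 to compound 4 (0.05 log units; within the scatter). Within the data shown here, this is a first measured step at this position, and it shows that a phenyl ring carrying two chlorine atoms can stand here in place of one carrying a single fluorine without a change that can be told apart from the scatter. No measurement shown here accounts for this result.

Going by these compounds, this one step changes both the kind of halogen and the number of halogens, so the share of each stays unknown. On these data alone, it also remains open whether the position would accept a phenyl ring carrying a carboxylic acid or an amine, groups quite unlike the halogens seen so far.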